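This account rests on a few compounds, and the source may have more. Where it says the series, first, only, none or still open, it means among the compounds named here.

In a functional assay on HeLa cells (Homo sapiens) for inhibition, read by CCK-8 assay, with a stated time of 72 h (a higher number here means a weaker inhibitor, a lower number a stronger inhibitor), three compounds built on a shared core have been measured so far: compound 1 `O=C(/C=C/c1cccnc1)NCCCCCCc1cccc(S(=O)(=O)Nc2ccccc2)c1` gives 30.4 nM, compound 2 `Cc1ccccc1NS(=O)(=O)c1cccc(CCCCCCNC(=O)/C=C/c2cccnc2)c1` gives 2.34 nM, and compound 3 `CCc1ccc(NS(=O)(=O)c2cccc(CCCCCCNC(=O)/C=C/c3cccnc3)c2)cc1` gives 132 nM. Compound 3 therefore has the highest number of the three and is the weakest inhibitor in the set, with its steps to both others beyond the scatter.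

The next compound is compound 4 `CC(C)(C)c1ccc(NS(=O)(=O)c2cccc(CCCCCCNC(=O)/C=C/c3cccnc3)c2)cc1`, which has tert-butyl in place of ethyl on an aromatic carbon, para to a large group (tert-butyl in place of ethyl on an aromatic carbon).

The measured step closest to this change is the one that introduced the ethyl group, a 4.3-fold higher number from compound 1 to compound 3 (0.64 log units; beyond the scatter), which is modest in size. Adding a group does not raise the number in every case, and compound 2 goes against that trend: a 13-fold lower number from compound 1 to compound 2 (1.11 log units; beyond the scatter) is large and runs the other way, with methyl in place of hydrogen, while a 56-fold higher number from compound 2 to compound 3 (1.75 log units; beyond the scatter) is also large. Only the ethyl step involves the group now being replaced, so it carries the most weight here, though it is a single precedent.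

A modest move toward a higher number, meaning a weaker inhibitor, is expected in this assay, with an estimated 2.3-fold higher number from compound 3 to compound 4 (0.36 log units; beyond the scatter). The estimated value for compound 4 is 300 nM, with an expected range of 80 nM to 1100 nM.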

Compound 4, half-maximal inhibitory concentration: 1520 nM
Estimate against measurement, compound 4: 5.1-fold (0.70 log units) below, and the stated range ends below it.
By their numbers in this assay, from the lowest: compound 2; then compound 1; then compound 3; then compound 4.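

In this assay, the change at this position from ethyl to tert-butyl gives a larger step (a 12-fold higher number from compound 3 to compound 4 (1.06 log units; beyond the scatter)) than the one that introduced ethyl (a 4.3-fold higher number from compound 1 to compound 3 (0.64 log units; beyond the scatter)). Across compound 1, compound 3 and compound 4, the number therefore rises at each replacement on this aromatic carbon, para to a large group, from hydrogen to ethyl to tert-butyl, and the full change is large (a 50-fold higher number from compound 1 to compound 4 (1.70 log units; beyond the scatter)). Compound 2, with its 2-methylphenyl on the sulfonamide nitrogen, goes against this rise, and replacing that group with 4-(tert-butyl)phenyl gives the widest step in the set (a 650-fold higher number from compound 2 to compound 4 (2.81 log units; beyond the scatter)). No measurement shown here accounts for these differences.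

The compounds shown leave open whether a methyl, a methoxy or a chlorine on this same aromatic carbon would fall in line with the rise from hydrogen to tert-butyl. Among the compounds shown here, they also leave open whether ethyl or tert-butyl on the ring carbon that carries the methyl of compound 2 would keep a number close to the one that compound gives.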